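Replacing the imidazole arm with thiophene in the shared core

This account rests on a few compounds, and the source may have more. Where it says the series, first, only, none or still open, it means among the compounds named here.

Compound 1 `CC(C)c1[nH]cnc1/C=c1\[nH]c(=O)/c(=C/c2cccc(Oc3ccc(F)cc3)c2)[nH]c1=O` is the reference point of this account. In a functional assay on NCI-H460 cells (Homo sapiens) for cytotoxicity, read by MTT assay, with a stated time of 72 h (on this read-out higher numbers stand for weaker inhibition and lower numbers for stronger inhibition), compound 1 gives 8.8 nM, the lowest of the two numbers that were read; the nearest is compound 3 `O=c1[nH]/c(=C\c2ccco2)c(=O)[nH]/c1=C\c1cccc(Oc2ccc(F)cc2)c1`, which in this assay gives 155 nM. For compound 2 `O=c1[nH]/c(=C\c2ncc[nH]2)c(=O)[nH]/c1=C\c1cccc(Oc2ccc(F)cc2)c1` only a limit of the assay is known, > 1000 nM in this assay. Compound 4 `O=c1[nH]/c(=C\c2cccs2)c(=O)[nH]/c1=C\c1cccc(Oc2ccc(F)cc2)c1` has not yet been measured. It differs from compound 1 in one place: thiophen-2-yl in place of 5-isopropyl-1H-imidazol-4-yl on a double-bonded chain carbon bound to an aromatic carbon. For the measured compounds named here, two measured steps bear on this change. The step of an 18-fold higher number from compound 1 to compound 3 (1.25 log units; beyond the scatter) shows that a furan-2-yl in the same place costs a large amount, and the step of an at least 110-fold higher number from compound 1 to compound 2 (2.05 log units; beyond the scatter) shows that a 1H-imidazol-2-yl costs even more, although that step rests on a limit (the limit of > 1000 nM in this assay, at which 1 of the 3 values shown sits). Thiophen-2-yl resembles furan-2-yl most closely, so a large rise in the number is expected for compound 4, roughly a 17-fold higher number from compound 1 to compound 4 (1.23 log units; beyond the scatter). Compound 4 is therefore estimated at 150 nM in this assay, with a range of 50 nM to 500 nM.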

Compound 4, half-maximal inhibitory concentration: > 1000 nM
Compound 4: a limit, no number; the forecaster's own chance of this, stated with the estimate: 10%; at least 6.6-fold (0.82 log units) between middle value and limit.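

In this assay compound 4 gives > 1000 nM, which is a limit of the assay and not a number, and the loss at this place is an at least 110-fold higher number from compound 1 to compound 4 (2.05 log units; beyond the scatter). The result also shows that furan-2-yl and thiophen-2-yl are not interchangeable on this double-bonded chain carbon, even though each is a five-membered aromatic ring with 1 hetero atom: the step is an at least 6.4-fold higher number from compound 3 to compound 4 (0.80 log units; beyond the scatter). The step between compound 2 and compound 4 cannot be read, because both compounds stand at a limit: the limit of > 1000 nM in this assay, at which 2 of the 4 values shown sit.

From the compounds shown here alone, how far compound 4 lies past its limit remains open. Also open, going by these compounds, is whether the isopropyl group or the way the imidazole is attached matters more for the value of compound 1, a question that a 1H-imidazol-4-yl arm without the isopropyl group, or one carrying a tert-butyl group instead, would address.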